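Swapping chloro for cyano on the aromatic ring

This account rests on a few compounds, and the source may have more. Where it says the series, first, only, none or still open, it means among the compounds named here.

In a functional assay on U-373MG ATCC cells (Homo sapiens) for inhibition, read by MTT assay, with a stated time of 72 h (on this read-out lower numbers stand for stronger inhibition and higher numbers for weaker inhibition), compound 1 `CC1(C)CC(NC(=S)Nc2cccc(Cl)c2)c2cc(Br)ccc2O1` gives 8000 nM while compound 2 `COc1ccccc1NC(=S)NC1CC(C)(C)Oc2ccc(Br)cc21` gives 22000 nM and compound 3 `CC1(C)CC(NC(=S)Nc2ccc(Cl)cc2)c2cc(Br)ccc2O1` gives 7000 nM on the same scale. Compound 3 thus sits level with compound 1 at the low end of these three numbers, and compound 2 stands apart from both. Shifting the chloro group around the ring gives a 1.1-fold lower number from compound 1 to compound 3 (0.06 log units; within the scatter) as its result, whereas swapping it for the methoxy group of compound 2 gives a 2.8-fold higher number from compound 1 to compound 2 (0.44 log units; beyond the scatter) on this scale.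

Compound 4 `CC1(C)CC(NC(=S)Nc2ccc(C#N)cc2)c2cc(Br)ccc2O1` has not been measured yet. It keeps the core of compound 3 and changes one group, 4-chlorophenyl to 4-cyanophenyl, with cyano in place of chloro on an aromatic carbon para to a large group. Among the compounds with values here, no measured step makes this exact exchange, so the swaps on the same ring are the nearest guide. The largest of them is a 3.1-fold lower number from compound 2 to compound 3 (0.50 log units; beyond the scatter) and is only modest, so a small step is expected in this assay with its direction open and leaning slightly towards a higher number. The estimated step is a 1.3-fold higher number from compound 3 to compound 4 (0.11 log units; within the scatter) and no change beyond the scatter is expected. For compound 4 the estimate is 9000 nM with 4000 nM to 20000 nM as the expected span.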

Compound 4, half-maximal inhibitory concentration: 22000 nM
For compound 4 the middle estimate is 2.4-fold (0.39 log units) below the measured one, outside the stated range (above it).
By their numbers in this assay, from the lowest: compounds 3 and 1 (each within the scatter of the next); then compounds 2 and 4 (each within the scatter of the next).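

The change from chloro to cyano brings a 3.1-fold higher number from compound 3 to compound 4 (0.50 log units; beyond the scatter) in this assay and so shows that the group at this place on the aromatic ring does matter, which moving the chlorine in a 1.1-fold lower number from compound 1 to compound 3 (0.06 log units; within the scatter) had not revealed. The nitrile also places compound 4 level with the methoxy compound, with no change at the digits printed from compound 2 to compound 4 (within the scatter) as the reading, and a 2.8-fold higher number from compound 1 to compound 4 (0.44 log units; beyond the scatter) gives the same picture against the other chloro compound. Across these four compounds, the two with a chlorophenyl group share the lower numbers and the two without one share the higher numbers, with no compound going against this, although four compounds are too few to make it a general rule.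

As far as these compounds go, whether a different group at this place, such as a fluorine, an amine or a carboxylic acid, would stay level with the chloro compounds or move with the nitrile remains open. Nothing measured here explains why the nitrile gives a higher number than the chlorine it replaces.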